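A Small Change at the Aryl Ether, Cytotoxicity Expected Unchanged

The compounds below may be only part of what the source reports. "The series", "measured", "known", "first", "only" and "open" are said of these compounds alone.

In an ADME assay on HepG2 cells (Homo sapiens) for cytotoxicity, read by luminescence, CellTiter-Glo and ATP content, with a stated time of 72 h (on this read-out lower numbers stand for an effect already at smaller amounts and higher numbers for an effect only at larger amounts of compound), compound 1 `COc1cccc(Oc2ccc3c(NCCCNCc4cc(F)ccc4OC)ccnc3c2)c1` gives 7100 nM, compound 2 `COc1ccc(F)cc1CNCCCNc1ccnc2cc(Cc3ccc(F)cc3)ccc12` gives 3530 nM, and compound 3 `COc1ccc(F)cc1CNCCCNc1ccnc2cc(Oc3ccc(Cl)cc3)ccc12` gives 4500 nM. Compound 3 has the second highest of the three numbers; its nearest neighbour is compound 2, with a 1.3-fold higher number from compound 2 to compound 3 (0.11 log units; within the scatter), and its furthest is compound 1, with a 1.6-fold lower number from compound 1 to compound 3 (0.20 log units; within the scatter). Compound 4 `COc1ccc(F)cc1CNCCCNc1ccnc2cc(Oc3cccc(N(C)C)c3)ccc12` differs from compound 3 by 3-(dimethylamino)phenyl in place of 4-chlorophenyl on an oxygen on an aromatic ring. For the measured compounds named here, the measured step that bears on this is the one that altered the group on the same oxygen, a 1.6-fold lower number from compound 1 to compound 3 (0.20 log units; within the scatter), which stayed within the scatter. No step beyond the scatter is therefore expected in this assay. Compound 4 is expected to give 4500 nM, with a range from 2000 nM to 10000 nM. That estimate means no change at the digits printed from compound 3 to compound 4 (within the scatter).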

Compound 4, half-maximal effective concentration: 3300 nM
Estimate against measurement, compound 4: 1.4-fold (0.13 log units) above; the range from low to high includes it.
By their numbers in this assay, from the lowest: compounds 4, 2, 3 and 1 (each within the scatter of the next, the first and the last beyond it).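

Replacing 4-chlorophenyl on this oxygen with 3-(dimethylamino)phenyl, a group that brings in nitrogen, yields only a small step in this assay with a 1.4-fold lower number from compound 3 to compound 4 (0.13 log units; within the scatter) and the comparison with the 4-fluorobenzyl compound also stays small with a 1.1-fold lower number from compound 2 to compound 4 (0.03 log units; within the scatter). For the compounds shown here, exchanging methoxy for dimethylamino on the same ring gives the first step in this set beyond the scatter, though a modest one, with a 2.2-fold lower number from compound 1 to compound 4 (0.33 log units; beyond the scatter). Nothing measured here accounts for that step. As far as these compounds go, it remains open whether a pyrrolidine or a carboxylic acid in place of dimethylamino would move the number further.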